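A Methoxy Group on the Benzyl Ring of Compound 1

The source may report more compounds than this note shows. Statements on the series, on what has been measured and on what is new or still open speak of the compounds shown alone.

Measured compounds:
compound 1, `O=c1ccoc2cc(OCc3cn(Cc4ccccc4)nn3)ccc12`: > 100000 nM
compound 2, `O=c1ccoc2cc(OCc3cn(Cc4cccc(Cl)c4)nn3)ccc12`: 28400 nM
compound 3, `CC(C)(C)c1ccc(Cn2cc(COc3ccc4c(=O)ccoc4c3)nn2)cc1`: > 100000 nM

In a functional assay on QGY7701 cells (Homo sapiens) for cytotoxicity, read by MTT assay, with a stated time of 48 h (on this read-out lower numbers stand for stronger inhibition and higher numbers for weaker inhibition), compound 1 gives > 100000 nM, which is a limit of the assay and not a number. Compound 3 also stands at a limit, > 100000 nM. Compound 2 gives a number, 28400 nM. Two single changes on the benzyl ring of compound 1 have been followed. Chloro in place of hydrogen on an aromatic carbon gives an at least 3.5-fold lower number from compound 1 to compound 2 (0.54 log units; beyond the scatter). The change to a tert-butyl group gives a step that the two limits leave unreadable from compound 1 to compound 3, because the limit of > 100000 nM in this assay, at which 2 of the 3 values shown sit, hides any movement there.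

Compound 4 is `COc1ccc(Cn2cc(COc3ccc4c(=O)ccoc4c3)nn2)cc1`. It differs from compound 1 by methoxy in place of hydrogen on an aromatic carbon. Only the chloro step bears on it, and that step is at least modest; the tert-butyl step gives no reading. With two of three values at a limit, compound 4 is expected to stay at or near that limit, so the expected step is a number no higher from compound 1 to compound 4 (the limit leaves the size open). The estimate for compound 4 in this assay is 100000 nM, with a range from 30000 nM to 300000 nM.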

Compound 4, half-maximal inhibitory concentration: 56600 nM
For compound 4 the middle estimate is 1.8-fold (0.25 log units) above the measured one, and the stated range covers the measured number.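

In this assay, compound 4 gives a readable number with a group at the place para to a large group, so a methoxy at this position is compatible with a measurable effect on these cells. The gain over the plain benzyl ring and over the tert-butyl group cannot yet be sized, as there is an at least 1.7-fold lower number from compound 1 to compound 4 (0.24 log units; that floor lies within the scatter) and also an at least 1.7-fold lower number from compound 3 to compound 4 (0.24 log units; that floor lies within the scatter), and both figures are only floors whose true size stays hidden for one reason: the limit of > 100000 nM in this assay, at which 2 of the 4 values shown sit. Set against the chloro compound, there is a 2.0-fold higher number from compound 2 to compound 4 (0.30 log units; within the scatter), so compound 2 and compound 4 cannot be told apart, and the two different ring changes give results that lie within the normal spread of this test.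

From the compounds shown here alone, it remains open whether another group at this same place, such as an amine, a carboxylic acid or a longer chain ending in oxygen, would bring the number clearly lower. Going by these compounds, it is also open how chloro would behave at this place, and how methoxy would behave at the ring position that chloro holds in compound 2.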